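Phenethyl replaces 4-chlorobenzyl at the sulfur of compound 3

The source may report more compounds than this note shows. Statements on the series, on what has been measured and on what is new or still open speak of the compounds shown alone.

Of the compounds shown here, three sharing one core have been tested in a toxicity assay on GES1 cells (Homo sapiens) for inhibition, read by MTT assay, with a stated time of 72 h; a lower number here means a stronger inhibitor, a higher number a weaker inhibitor. Compound 1 `Cc1cc(N2CC[C@@H](C)[C@@H](N(C)c3ncnc4[nH]ccc34)C2)n2nc(SCc3ccc(C(F)(F)F)cc3)nc2n1` gives 17300 nM. Compound 2 `Cc1cc(N2CC[C@@H](C)[C@@H](N(C)c3ncnc4[nH]ccc34)C2)n2nc(SCC3CC3)nc2n1` gives 27900 nM. Compound 3 `Cc1cc(N2CC[C@@H](C)[C@@H](N(C)c3ncnc4[nH]ccc34)C2)n2nc(SCc3ccc(Cl)cc3)nc2n1` reaches only a limit of the assay, > 100000 nM, so its standing among the three is known just as an edge: the step of an at least 5.7-fold higher number from compound 1 to compound 3 (0.76 log units; beyond the scatter) and the step of an at least 3.5-fold higher number from compound 2 to compound 3 (0.55 log units; beyond the scatter) are both read from that limit, (the limit of > 100000 nM in this assay, at which 1 of the 3 values shown sits).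

Compound 4 `Cc1cc(N2CC[C@@H](C)[C@@H](N(C)c3ncnc4[nH]ccc34)C2)n2nc(SCCc3ccccc3)nc2n1` differs from compound 3 by benzyl in place of 4-chlorophenyl on a saturated chain carbon bound to a sulfur. Going by the values given here, no measured step changes the chain length at the sulfur, and the steps that touch the group on that chain carbon, an at least 3.5-fold higher number from compound 2 to compound 3 (0.55 log units; beyond the scatter) and a 1.6-fold higher number from compound 1 to compound 2 (0.21 log units; within the scatter), only bracket where the substituent matters. The loss of the chloro is the nearest point of reference, since the chloro-bearing compound 3 sits at the limit while compound 1 and compound 2 sit well inside the measured range. He therefore expects a step of an at least 2.0-fold lower number from compound 3 to compound 4 (0.30 log units; that floor lies within the scatter) in this assay, and estimates compound 4 at 50000 nM, within 15000 nM to 150000 nM.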

Compound 4, half-maximal inhibitory concentration: 66200 nM
For compound 4 the middle estimate is 1.3-fold (0.12 log units) below the measured one, within the range that was stated.
By their numbers in this assay, from the lowest: compounds 1 and 2 (each within the scatter of the next); then compound 4. At a limit, above all of these: compound 3.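

In this assay, phenethyl at the sulfur gives a higher number than either of the two other groups with measured values: a 2.4-fold higher number from compound 2 to compound 4 (0.38 log units; beyond the scatter) and a 3.8-fold higher number from compound 1 to compound 4 (0.58 log units; beyond the scatter). Compound 4 therefore stays inside the measured range, yet it stands apart from compound 1 and compound 2, which lie within the scatter of each other. The step of an at least 1.5-fold lower number from compound 3 to compound 4 (0.17 log units; that floor lies within the scatter) can be read only as a floor, because compound 3 stands at a limit of the assay: the limit of > 100000 nM in this assay, at which 1 of the 4 values shown sits.

Compound 4 differs from compound 3 both in losing the chloro and in the longer chain at the sulfur, so the compounds shown do not tell which of the two carries the change. As far as these compounds go, whether a 4-chlorophenethyl group would stay at the limit, or a phenethyl ring bearing an amine or a carboxylic acid would shift the number, remains open.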